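Chain extension at the aryl substituent: working notes

The source may report more compounds than this note shows. Statements on the series, on what has been measured and on what is new or still open speak of the compounds shown alone.

Measured so far, in a functional assay on the whole organism with Rattus norvegicus as the target, at a dose of 3 mg/kg by the oral route; on this read-out lower numbers stand for a weaker effect and higher numbers for a stronger effect at the one dose given:
compound 1 `CCc1ccc(-c2cc(Cl)cc(C(=O)Nc3nn[nH]n3)n2)cc1` gives 100%
compound 2 `CC(C)c1ccc(-c2cc(Cl)cc(C(=O)Nc3nn[nH]n3)n2)cc1` gives 68%
compound 3 `CCCc1ccc(-c2cc(OC)cc(C(=O)Nc3nn[nH]n3)n2)cc1` gives 93%

The one counted change among the measured compounds is from compound 1 to compound 2:
methyl in place of hydrogen on a saturated chain carbon bound to an aromatic carbon and a saturated chain carbon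
In this assay it made a step of a number 32 percentage points lower from compound 1 to compound 2 (beyond the scatter).

Compound 3 and compound 1 have different cores; that difference is not broken down here. Their values lie within the scatter of each other, so no order is read between them.

The unmeasured compound 4 `CCCCc1ccc(-c2cc(OC)cc(C(=O)Nc3nn[nH]n3)n2)cc1` differs from compound 3 thus:
methyl in place of hydrogen on a saturated chain carbon, three bonds along the chain from an aromatic carbon
Among the measured compounds shown here, this is the same kind of change as the one from compound 1 to compound 2, but not the same: there the methyl entered on a saturated chain carbon bound to an aromatic carbon and a saturated chain carbon, here it enters on a saturated chain carbon, three bonds along the chain from an aromatic carbon. For the measured compounds named here, the earlier step is the only guide, and it was made at a different place on the chain and on a different core, so it is taken with caution.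

For compound 4 a step of a number 18 percentage points lower from compound 3 to compound 4 (beyond the scatter) in this assay is expected, smaller than the earlier one, resting on the drop from compound 1 to compound 2 of a number 32 percentage points lower from compound 1 to compound 2 (beyond the scatter). Compound 4 is estimated at 75%, between 45% and 95%.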

Compound 4, a percentage reported as inhibition, in the whole organism at one dose (the size of the read-out at that dose, not a potency): 61%
Beside the measured number, compound 4's estimate is 14 percentage points above it, within the range that was stated.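

The added methyl gave a number 32 percentage points lower from compound 3 to compound 4 (beyond the scatter) in this assay. Set beside the earlier step, the size of this change carried over from one core to the other: the same change on two cores in this assay, a number 32 percentage points lower (beyond the scatter) from compound 1 to compound 2 and a number 32 percentage points lower (beyond the scatter) from compound 3 to compound 4, 0 percentage points apart, within the scatter of two such steps

This agreement rests on one pair of compounds per core, and the methyl entered at a different place in each pair, so it shows matching step sizes for these two pairs only and gives no rule for other cores or other places on the chain; the read-out also gives the size of the effect at one dose, not a potency.

The compounds shown leave open whether a step of this size would recur on a third core, and how the branched and straight chains would compare on a single core. Also open, going by these compounds, is what a longer chain such as pentyl, or an amine or a carboxylic acid carried on the chain, would give in this assay.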